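Two fragments of a series on cell activity

The source may hold more compounds than are shown below. What is called first, only, known or untested is meant among the compounds shown, and "the series" means these compounds.

Measured compounds:
compound 1, `CCSC[C@@](O)([C@@H](Nc1cccc2nc(C)ccc12)c1ccc(F)cc1OC)C(F)(F)F`, 5.01 nM in a functional assay on THP-1 cells (Homo sapiens); a higher number here means a weaker inhibitor, a lower number a stronger inhibitor
compound 2, `COc1ccc([C@H](Nc2cccc3nc(C)ccc23)[C@](O)(CSC)C(F)(F)F)c(Cl)c1F`, 0.126 nM in this assay

Compound 2 carries the lower of the two numbers in this assay; the gap to compound 1 lies beyond the scatter, so compound 2 stands as the stronger of the two on these figures.

Compound 3, `COc1ccc([C@H](Nc2cccc3nc(C)ccc23)[C@](O)(CN(C)C)C(F)(F)F)c(Cl)c1F`, is not yet measured. It differs from compound 2 in one place: dimethylamino in place of methylsulfanyl on a saturated chain carbon, two bonds along the chain from an oxygen on a saturated carbon. Among the measured compounds shown here, no pair of measured compounds shows this exchange, so nothing in the data fixes its size or direction.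

With compound 2 as the only anchor, the step from compound 2 to compound 3 is expected to be a small weakening, a 3.2-fold higher number from compound 2 to compound 3 (0.50 log units; beyond the scatter), not far beyond the scatter. Compound 3 is therefore estimated at 0.4 nM in this assay, with a range of 0.08 nM to 2 nM.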

Compound 3, half-maximal inhibitory concentration in the THP-1 assay: 5.01 nM
The estimate for compound 3 lay 13-fold (1.10 log units) below the measured number; the measured number lies above the stated range.
By their numbers in the THP-1 assay, from the lowest: compound 2; then compounds 1 and 3 (each within the scatter of the next).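

In the THP-1 assay, this position proves sensitive to what sits on the saturated chain carbon: dimethylamino in place of methylsulfanyl gives a 40-fold higher number from compound 2 to compound 3 (1.60 log units; beyond the scatter). Among the compounds shown here, compound 1 and compound 2 differ in more than one place, so this pair is the first to isolate a single change here, and the step is large although both groups are small, ringless and carry the same count of hydrogen-bond donors and acceptors. In a physicochemical assay for lipophilicity (on this read-out higher numbers stand for higher lipophilicity and lower numbers for lower lipophilicity), compound 2 gives 4.5 and compound 3 gives 5.3 on this read-out. The weakening comes with a rise in lipophilicity in the physicochemical assay, though one pair cannot link the two: the measured partition coefficient of compound 2, 4.5, and of compound 3, 5.3, a number 0.80 log units higher (beyond the scatter)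

The compounds shown leave open whether another group on this carbon, such as methoxy, a primary amine or a morpholine, would stay close to compound 2 or fall away as compound 3 does. Going by these compounds, whether the exchange has the same size on the core of compound 1 also stays open.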